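The source may hold more compounds than are shown below. What is called first, only, known or untested is meant among the compounds shown, and "the series" means these compounds.

Compound 1 `COc1ccc(NC(=O)c2cn(-c3ccccc3)nc2-c2ccccc2)cc1`: 1710 nM
Compound 2 `COc1ccc(NC(=O)c2cn(-c3ccccc3)nc2-c2ccc(C)cc2)cc1`: 1620 nM
Compound 3 `O=C(Nc1ccccc1)c1cn(-c2ccccc2)nc1-c1ccc([N+](=O)[O-])cc1`: 2260 nM

Of the compounds shown here, three built on a shared core have been tested in a functional assay on MCF7 cells (Homo sapiens) for cytotoxicity, read by MTT assay, with a stated time of 48 h; a lower number here means a stronger inhibitor, a higher number a weaker inhibitor. In this assay compound 1 gives 1710 nM, compound 2 gives 1620 nM, and compound 3 gives 2260 nM. Compound 3 holds the highest of the three numbers, yet its gaps to compound 1 and to compound 2 both lie within the scatter, so no ranking among the three can be drawn from these numbers.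

Compound 4 `COc1ccc(NC(=O)c2cn(-c3ccccc3)nc2-c2ccc([N+](=O)[O-])cc2)cc1` has not yet been measured. It differs from compound 3 in one place: methoxy in place of hydrogen on an aromatic carbon. Within the data shown here, the only single-point step among the measured compounds is a 1.1-fold lower number from compound 1 to compound 2 (0.02 log units; within the scatter), which concerns a different group on a different ring and so offers only indirect guidance. Compound 1 and compound 3 differ in two places at once, and their two values sit within the scatter of each other. With nothing beyond the scatter anywhere in the measured set, the step expected from compound 3 to compound 4 is a 1.1-fold lower number from compound 3 to compound 4 (0.05 log units; within the scatter), a change no larger than the scatter in either direction. Compound 4 is therefore estimated at 2000 nM, with a range from 1000 nM to 4000 nM.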

Compound 4, half-maximal inhibitory concentration: 1210 nM
Compound 4: middle estimate off by 1.7-fold (0.22 log units), on the high side, within the range that was stated.
By their numbers in this assay, from the lowest: compounds 4, 2, 1 and 3 (each within the scatter of the next).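

In this assay, among these compounds, methoxy in place of hydrogen on the anilino group, para to a large group, gives a 1.9-fold lower number from compound 3 to compound 4 (0.27 log units; within the scatter) and offers the first direct reading of this change at this place, which shows no shift beyond the scatter. With that methoxy kept in place, compound 4 also completes a set of three on the other phenyl ring: nitro in place of methyl gives a 1.3-fold lower number from compound 2 to compound 4 (0.13 log units; within the scatter) while nitro in place of hydrogen gives a 1.4-fold lower number from compound 1 to compound 4 (0.15 log units; within the scatter) and so hydrogen, methyl and nitro at that place, in compounds 1, 2 and 4, all sit within the scatter of one another. No other measurement accompanies these numbers, so the data offer no explanation for any of these small steps.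

From the compounds shown here alone, every step read so far lies within the scatter, so it remains open whether any change at these two places can move the number by more than that. An amine or a carboxylic acid in place of the methoxy, or a longer chain such as butoxy, would test this at the anilino position.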